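A Dichlorophenyl for Pyridyl Swap in a Flat Series

This account rests on a few compounds, and the source may have more. Where it says the series, first, only, none or still open, it means among the compounds named here.

Compound 1, `CC(C)Cc1csc(N)c1C(=O)c1ccc(Cl)cc1`: 1%
Compound 2, `Cc1c(Br)sc(N)c1C(=O)c1ccc(Cl)cc1`: 1%
Compound 3, `CC(C)(C)Cc1c(-c2cccnc2)sc(N)c1C(=O)c1ccc(Cl)cc1`: 1%

These three compounds share one core and were tested in an assay on CHO cells for displacement of a labelled ligand from adenosine receptor A3 (Homo sapiens), read by scintillation counting, tested at 10 uM; a lower number here means less inhibition, a higher number more inhibition at the concentration tested (going by the name of the read-out). Compound 3 stands level with compounds 1 and 2 at the digits reported. Its nearest neighbour is compound 1 and its furthest is compound 2, and in both cases there is no change at the digits reported, within the scatter.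

Compound 4, `CC(C)(C)Cc1c(-c2ccc(Cl)c(Cl)c2)sc(N)c1C(=O)c1ccc(Cl)cc1`, has not yet been measured. It differs from compound 3 in one place: 3,4-dichlorophenyl in place of pyridin-3-yl on an aromatic carbon.

Within the data shown here, no step between measured compounds is available, so nothing is known here about what such a change does. Every measured compound gives a reading at the bottom of the scale. The step from compound 3 to compound 4 is expected to be a number 2 percentage points higher from compound 3 to compound 4 (within the scatter), nothing beyond the scatter. Compound 4 is therefore estimated at 3%, with a range from -8% to 18%.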

Compound 4, a percentage reported as inhibition, at one concentration (the size of the read-out at that concentration, not a potency): 1%
The estimate for compound 4 lay 2 percentage points above the measured number; measured number inside the range.
By their numbers in this assay, from the lowest: compounds 1, 2, 3 and 4 (each within the scatter of the next).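

In this assay, among these compounds, putting 3,4-dichlorophenyl in place of pyridin-3-yl on the aromatic carbon next to the ring sulfur gives no change at the digits printed from compound 3 to compound 4 (within the scatter) as the first one-place comparison in this set. At this position, then, exchanging a ring with one hetero atom for a ring of carbon only does not lift the reading off the bottom of the scale. No measurement here offers an explanation for this result.

With every reading this low, the step cannot show whether either ring matters at all. As far as these compounds go, whether an amine or a carboxylic acid on this carbon would raise the reading remains open.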